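A Bigger Arm on a Shared Amide Core

A few compounds are considered here, and "the series" means these few. Any claim that something is new, unique, unknown or untested is made for them only; others in the source may bear on it.

compound 1 `CC(C)(C)NC(=O)CCc1cccc2c1B(O)OC2` — in a functional assay on MDA-MB-231 cells (Homo sapiens) for antiproliferative activity, read by MTT assay, with a stated time of 72 h (on this read-out higher numbers stand for weaker inhibition and lower numbers for stronger inhibition), compound 1 gives > 100000 nM, a limit of the assay.
compound 2 `CCOC(=O)c1ccc(NC(=O)CCc2cccc3c2B(O)OC3)cc1` — in this assay compound 2 gives > 100000 nM, also a limit.
compound 3 `C#Cc1cccc(NC(=O)CCc2cccc3c2B(O)OC3)c1` — in this assay compound 3 gives 1600 nM.

Among the compounds with values here, compound 3 therefore stands alone with the only measured number; the other two sit at the limit of > 100000 nM in this assay, at which 2 of the 3 values shown sit. Compound 4 `CSc1ccc(-c2cccc(NC(=O)CCc3cccc4c3B(O)OC4)c2)cc1` differs from compound 3 by 4-(methylsulfanyl)phenyl in place of ethynyl on an aromatic carbon. Within the data shown here, no measured pair shows a change of this kind, so the size of the step cannot be read from the data. I expect a step of a 1.6-fold lower number from compound 3 to compound 4 (0.20 log units; within the scatter) toward stronger inhibition, of a size that may not go beyond the scatter. Compound 4 is estimated at 1000 nM, expected between 200 nM and 8000 nM.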

Compound 4, half-maximal inhibitory concentration: 140 nM
Beside the measured number, compound 4's estimate is 7.1-fold (0.85 log units) above it; the whole stated range lies above it.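

Within the data shown here, putting 4-(methylsulfanyl)phenyl in place of ethynyl gives an 11-fold lower number from compound 3 to compound 4 (1.06 log units; beyond the scatter) and is the first step in this set that can be read. The earlier compounds shown here offered no such pair, so only now is it visible that this aromatic carbon, meta to a large group, can carry a much bigger arm with an added aromatic ring and still give stronger inhibition in this assay as well.

From the compounds shown here alone, how a plain phenyl, or a ring carrying an amine or a carboxylic acid instead of methylsulfanyl, would read stays open. No measurement shown accounts for the size of this step.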